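The compounds below may be only part of what the source reports. "The series", "measured", "known", "first", "only" and "open" are said of these compounds alone.

Measured compounds:
- compound 1 `O=C(NNc1ccccc1Cl)c1ccc(NS(=O)(=O)c2cnc(O)nc2O)cc1`, in a functional assay on OVCAR-3 cells (Homo sapiens) for antiproliferative activity, read by MTT assay, with a stated time of 24 h (a lower number here means a stronger inhibitor, a higher number a weaker inhibitor), compound 1 gives 7230 nM
- compound 2 `Cc1cccc(NNC(=O)c2ccccc2NS(=O)(=O)c2cnc(O)nc2O)c1`, in this assay compound 2 gives only a limit, > 20000 nM
- compound 3 `O=C(NNC(=O)c1cccc(Cl)c1)c1ccc(NS(=O)(=O)c2cnc(O)nc2O)cc1`, in this assay compound 3 gives 7710 nM

Among the measured compounds shown here, compound 2 stands at the limit of this assay: its value is not a number but the boundary (the limit of > 20000 nM in this assay, at which 1 of the 3 values shown sits), and no step from it can be sized.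

Compound 4 `O=C(NNC(=O)c1ccccc1NS(=O)(=O)c1cnc(O)nc1O)c1ccccc1F` is derived from compound 2 by the change ((2-fluorophenyl)carbonyl in place of 3-methylphenyl on an amine nitrogen). For the measured compounds named here, the one measured step that bears on this kind of change is a 1.1-fold higher number from compound 1 to compound 3 (0.03 log units; within the scatter), where an acyl group took the place of an aryl group on the same amine nitrogen and the number did not move beyond the scatter. Compound 1 and compound 3, however, share a core arranged differently from that of compound 2 and compound 4, so the transfer is loose.

From this, the step of a number no higher from compound 2 to compound 4 (the limit leaves the size open) is expected to be small or absent, with compound 4 likely remaining at or near the limit. The estimate for compound 4 in this assay is 20000 nM, within a range of 7000 nM to 40000 nM, and a limit rather than a number is considered about as likely as not.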

Compound 4, half-maximal inhibitory concentration: 15300 nM
Compound 4: middle estimate off by 1.3-fold (0.12 log units), on the high side; low and high end bracket the measured number.
By their numbers in this assay, from the lowest: compounds 1, 3 and 4 (each within the scatter of the next, the first and the last beyond it). At a limit, above all of these: compound 2.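

In this assay, among the compounds shown here, the single change on the amine nitrogen whose other neighbour is an amide-type nitrogen gives an at least 1.3-fold lower number from compound 2 to compound 4 (0.11 log units; that floor lies within the scatter). For the compounds shown here, this is the first number on the core of compound 2, as compound 4 gives 15300 nM, so this position can be read on that core. The floor of the step supports no claim of a gain. Compound 2 has only a limit and not a number: the limit of > 20000 nM in this assay, at which 1 of the 4 values shown sits.

On these data alone, the true size of the step stays open, and so does whether the carbonyl or the fluorine matters, as the change alters both at once. Also open, as far as these compounds go, is how a carboxylic acid, an amine or a longer alkyl chain on this nitrogen would read on this core.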